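Ester to ether swap in a weakly cytotoxic series

The source may hold more compounds than are shown below. What is called first, only, known or untested is meant among the compounds shown, and "the series" means these compounds.

Measured compounds:
Compound 1 `CC(C)=CC[C@@H](OC(=O)c1ccoc1)C1=CC(=O)c2c(O)ccc(O)c2C1=O` – in a functional assay on HeLa cells (Homo sapiens) for cytotoxicity, read by MTT assay (on this read-out lower numbers stand for stronger inhibition and higher numbers for weaker inhibition), compound 1 gives only a limit, > 100000 nM.
Compound 2 `CC(C)=CC[C@@H](OC(=O)C1CCOC1)C1=CC(=O)c2c(O)ccc(O)c2C1=O` – in this assay compound 2 gives 73500 nM.

For the measured compounds named here, compound 2 holds the only number in the set; the other value is a limit, (the limit of > 100000 nM in this assay, at which 1 of the 2 values shown sits). Going by the values given here, the single measured step, an at least 1.3-fold lower number from compound 1 to compound 2 (0.13 log units; that floor lies within the scatter), lies within the scatter. Compound 3 `CCC(CO[C@H](CC=C(C)C)C1=CC(=O)c2c(O)ccc(O)c2C1=O)OC(C)=O` differs from compound 2 by 2-acetoxybutyl in place of (oxolan-3-yl)carbonyl on an oxygen on a saturated carbon. Among the compounds with values here, only that single measured step bears on this change, and it was small, so no shift beyond the scatter is expected in this assay. For compound 3 the estimated value is 70000 nM, ranging from 25000 nM to 200000 nM, which means an expected step of a 1.1-fold lower number from compound 2 to compound 3 (0.02 log units; within the scatter).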

Compound 3, half-maximal inhibitory concentration: 44000 nM
Compound 3: middle estimate off by 1.6-fold (0.20 log units), on the high side; low and high end bracket the measured number.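

The 2-acetoxybutyl group on this oxygen on a saturated carbon keeps the read-out in this assay within the scatter of the (oxolan-3-yl)carbonyl group, with a 1.7-fold lower number from compound 2 to compound 3 (0.22 log units; within the scatter), so neither the ring nor the carbonyl on this oxygen is needed to hold that level. Against the (furan-3-yl)carbonyl group, the same group gives an at least 2.2-fold lower number from compound 1 to compound 3 (0.35 log units; beyond the scatter), the only step in the set beyond the scatter. Compound 1 gives only a limit, so this step is a floor: the limit of > 100000 nM in this assay, at which 1 of the 3 values shown sits.

Open, going by these compounds, is whether the acetoxy part of the chain matters at all, as a plain butyl chain or an amine on the same chain would show. Also open, on these data alone, is whether any group on this oxygen moves the number well beyond the scatter of compound 2.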